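Series notes: the step from compound 3 to compound 4

This account rests on a few compounds, and the source may have more. Where it says the series, first, only, none or still open, it means among the compounds named here.

Three compounds have numbers in an assay on isolated protein for inhibition of DNA topoisomerase 1 (Homo sapiens), with a stated time of 30 min, tested at 100 uM; on this read-out lower numbers stand for a weaker effect and higher numbers for a stronger effect at the one concentration tested. Compound 1 `Cc1cccc(-c2nc3cc(C)ccc3c(=O)[nH]2)c1` gives 100%. Compound 2 `Cc1ccc2c(=O)[nH]c(-c3cccc(F)c3)nc2c1` gives 77.5%. Compound 3 `COc1cccc(-c2nc3cc(C)ccc3c(=O)[nH]2)c1` gives 100%, level with compound 1 and together with it the highest of the three numbers; the relevant steps are no change at the digits printed from compound 1 to compound 3 (within the scatter) and a number 22.5 percentage points higher from compound 2 to compound 3 (beyond the scatter). Compound 4 `Cc1ccc2c(=O)[nH]c(-c3cccc(OC(F)(F)F)c3)nc2c1` is not yet measured. It differs from compound 3 thus: trifluoromethyl in place of methyl on an oxygen on an aromatic ring. Within the data shown here, no measured step swaps these two groups. The nearest guides are no change at the digits printed from compound 1 to compound 3 (within the scatter) and the fluoro-bearing compound 2, reached by a number 22.5 percentage points lower from compound 1 to compound 2 (beyond the scatter). Compound 3 already stands at 100%, so any change can only show as a drop, and a small one is expected, a number 12 percentage points lower from compound 3 to compound 4 (beyond the scatter). Compound 4 is estimated at 88%, between 65% and 100%.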

Compound 4, a percentage reported as inhibition, at one concentration (the size of the read-out at that concentration, not a potency): 77.2%
Beside the measured number, compound 4's estimate is 10.8 percentage points above it; measured number inside the range.
By their numbers in this assay, from the lowest: compounds 4 and 2 (each within the scatter of the next); then compounds 1 and 3 (each within the scatter of the next).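

Replacing methoxy with trifluoromethoxy on the aromatic ring gives a clear fall (a number 22.8 percentage points lower from compound 3 to compound 4 (beyond the scatter)), and the step from the methyl-bearing compound is of the same printed size (a number 22.8 percentage points lower from compound 1 to compound 4 (beyond the scatter)). Trifluoromethoxy and fluoro cannot be told apart here (a number 0.3 percentage points lower from compound 2 to compound 4 (within the scatter)), so the four compounds form two groups: compounds 1 and 3 at the top, compounds 2 and 4 lower. No measurement available here accounts for this split.

As far as these compounds go, whether an amine or a carboxylic acid at this place would join the upper or lower group remains open. A single test concentration also leaves open whether compounds 1 and 3 would show a stronger or weaker effect than each other at any other concentration.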